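Removing the Bromine from Compound 2

The source may report more compounds than this note shows. Statements on the series, on what has been measured and on what is new or still open speak of the compounds shown alone.

Compound 2, `CCN(Cc1ccc(Br)cc1)Cc1nn(-c2ccccc2F)c2c1CCS(=O)(=O)O2`, is one of three close relatives built on a shared core. In a functional assay, with a stated time of 2 h, tested at 100 uM (a lower number here means less inhibition, a higher number more inhibition at the concentration tested (going by the name of the read-out)), compound 2 gives 12.9%. Compound 1, `CN(Cc1ccc(F)cc1)Cc1nn(-c2ccccc2F)c2c1CCS(=O)(=O)O2`, gives 5.7% in this assay, and compound 3, `CCN(Cc1ccc(Cl)cc1)Cc1nn(-c2ccccc2F)c2c1CCS(=O)(=O)O2`, gives 4.2%. Compound 2 thus stands at the top of the three numbers, yet all three lie within the usual scatter of one another, so no real ranking among them can be read from these data.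

Compound 4, `CCN(Cc1ccccc1)Cc1nn(-c2ccccc2F)c2c1CCS(=O)(=O)O2`, is still to be measured in this assay. It differs from compound 2 in one place: hydrogen in place of bromo on an aromatic carbon. For the measured compounds named here, the one measured step that bears on this change concerns the same aromatic carbon: a number 8.7 percentage points lower from compound 2 to compound 3 (within the scatter). Going by the values given here, that exchange of chloro for bromo stayed within the scatter, and no measured pair shows what the complete loss of the bromo does. On this basis the change to hydrogen is expected to move the number by no more than the scatter, so the step of a number 5.9 percentage points lower from compound 2 to compound 4 (within the scatter) is estimated to be small. Compound 4 is therefore expected to give about 7% in this assay, within a range from 0% to 18%.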

Compound 4, a percentage reported as inhibition, at one concentration (the size of the read-out at that concentration, not a potency): 1.8%
Compound 4: middle estimate off by 5.2 percentage points, on the high side, within the range that was stated.
By their numbers in this assay, from the lowest: compounds 4, 3, 1 and 2 (each within the scatter of the next, the first and the last beyond it).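

Going from 4-bromobenzyl to benzyl gives the first step on this aromatic carbon that clears the scatter in this assay, with a number 11.1 percentage points lower from compound 2 to compound 4 (beyond the scatter). Hydrogen in place of chloro on the same carbon gives only a number 2.4 percentage points lower from compound 3 to compound 4 (within the scatter), so of the two halogens compared here, only the bromo stands apart from hydrogen, and only modestly. The data shown offer no explanation for this difference between bromo and chloro.

Compound 1 carries fluoro but also methyl in place of ethyl on the amine, so it cannot show on its own how fluoro compares with hydrogen on this carbon. On these data alone, what a methoxy group, a trifluoromethyl group or an amine would do at this position remains open, as does whether any group there could raise the number well beyond that of compound 2.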